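The compounds below may be only part of what the source reports. "The series", "measured", "known", "first", "only" and "open" are said of these compounds alone.

Measured compounds:
Compound 1 `Fc1ccccc1N1CCN(Cn2nc(-c3ccc4c(c3)OCCO4)oc2=S)CC1`: in a functional assay on HepG2 cells (Homo sapiens) for antiproliferative activity, read by MTT assay, with a stated time of 48 h (on this read-out lower numbers stand for stronger inhibition and higher numbers for weaker inhibition), compound 1 reports a limit of > 50000 nM.
Compound 2 `COc1ccccc1N1CCN(Cn2nc(-c3ccc4c(c3)OCCO4)oc2=S)CC1`: in this assay compound 2 gives 15500 nM.

Compound 2 holds the only number shown; the other value is a limit (the limit of > 50000 nM in this assay, at which 1 of the 2 values shown sits). Going by the values given here, the single measured step, an at least 3.2-fold lower number from compound 1 to compound 2 (0.50 log units; beyond the scatter), is bounded in size by that limit (the limit of > 50000 nM in this assay, at which 1 of the 2 values shown sits). Compound 3 `Fc1ccc(N2CCN(Cn3nc(-c4ccc5c(c4)OCCO5)oc3=S)CC2)cc1` differs from compound 2 by 4-fluorophenyl in place of 2-methoxyphenyl on an amine nitrogen in a ring. Among the compounds with values here, no measured step covers this change, though the one step known shows a fluoro-to-methoxy swap moving the number beyond the scatter. Compound 3 is therefore expected to weaken, with an estimated step of a 2.6-fold higher number from compound 2 to compound 3 (0.41 log units; beyond the scatter). Compound 3 is estimated at 40000 nM, range 15000 nM to 110000 nM.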

Compound 3, half-maximal inhibitory concentration: > 50000 nM
Compound 3 ended at the assay's limit; the forecaster's own chance of this, stated with the estimate: 40%; at least 1.2-fold (0.09 log units) between middle value and limit.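

In this assay the 4-fluorophenyl group on the amine nitrogen in the ring, replacing 2-methoxyphenyl, gives an at least 3.2-fold higher number from compound 2 to compound 3 (0.50 log units; beyond the scatter) and leaves only a limit in place of a number. The step between the two fluorophenyl compounds, compound 1 and compound 3, cannot be read: both values are limits. Among the three compounds only the 2-methoxyphenyl group yields a number, and both fluorophenyl compounds sit at the same limit: the limit of > 50000 nM in this assay, at which 2 of the 3 values shown sit.

Open, going by these compounds, is whether a 4-methoxyphenyl group would keep a measurable number. Also open, on these data alone, is whether an unsubstituted phenyl or a pyridine ring in this place would do so.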